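Inverting One Stereocentre of Inactive Compound 2

This account rests on a few compounds, and the source may have more. Where it says the series, first, only, none or still open, it means among the compounds named here.

Of the compounds shown here, three have been tested so far in a functional assay on HL-60 cells (Homo sapiens) for antiproliferative activity, read by MTT assay (on this read-out lower numbers stand for stronger inhibition and higher numbers for weaker inhibition), and only one of them gives a number. Compound 1 `C=CC[C@@H]1O[C@H](COCc2ccccc2)[C@@H](OCc2ccccc2)[C@H](OCc2ccccc2)[C@@H]1O` is reported as "not active" (no number reported). Compound 2 `CCC[C@@H]1O[C@H](COCc2ccccc2)[C@@H](OCc2ccccc2)[C@H](OCc2ccccc2)[C@@H]1O` is also reported as "not active" (no number reported), so it has no single value and stands alongside compound 1 without a number. Compound 3 `O[C@@H]1[C@@H](OCc2ccccc2)[C@H](O)[C@@H](COCc2ccccc2)O[C@H]1Cc1ccccc1` gives 35300 nM.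

Compound 4 `CCC[C@H]1O[C@H](COCc2ccccc2)[C@@H](OCc2ccccc2)[C@H](OCc2ccccc2)[C@@H]1O` is the next one to place. The structural change is small: the two compounds have the same atoms and bonds and differ only in configuration as drawn: 1 of 5 stereo elements differ; a stereocentre at a saturated ring carbon is drawn S in compound 2 and R in compound 4. No atom leaves or enters.

For the measured compounds named here, no measured step shows what such an inversion does in this assay, and compound 2 offers no number to step from. The expected change is therefore none beyond the scatter, with compound 4 most likely remaining without a number. If it does give a number, that number is expected near the one for compound 3 at 35300 nM.

For compound 4 the estimated half-maximal inhibitory concentration is 40000 nM, with an expected range of 15000 nM to 100000 nM.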

Compound 4, half-maximal inhibitory concentration: "not active" (no number reported)
Nothing numeric was reported for compound 4, so the estimate cannot be set against anything.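

In this assay compound 2 gives "not active" (no number reported) and compound 4 gives "not active" (no number reported), so no step can be read between them. Whether this inversion has any effect on antiproliferative activity stays open, as the pair offers only this: the fact that compounds 2 and 4 differ only in the configuration as drawn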